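The source may report more compounds than this note shows. Statements on the series, on what has been measured and on what is new or still open speak of the compounds shown alone.

Measured compounds:
- compound 1 `CNC(=O)[C@H]1O[C@@H](n2cnc3c(NCc4cc(Cl)cc(Cl)c4)ncnc32)[C@H](O)[C@@H]1O`: 2.5 nM
- compound 2 `CNC(=O)[C@H]1O[C@@H](n2cnc3c(NCc4cc(OC)ccc4OC)ncnc32)[C@H](O)[C@@H]1O`: 3.9 nM
- compound 3 `CNC(=O)[C@H]1O[C@@H](n2cnc3c(NC)ncnc32)C[C@@H]1O`: 87 nM

In an assay on isolated protein for binding affinity to adenosine receptor A3 (Homo sapiens) (on this read-out higher numbers stand for weaker inhibition and lower numbers for stronger inhibition), compound 1 gives the lowest of the three numbers. Compound 2 lies nearest to it, and the step of a 1.6-fold higher number from compound 1 to compound 2 (0.19 log units; within the scatter) is within the scatter, so the two cannot be ordered. Within the data shown here, compound 3 stands furthest away, with a number well beyond the scatter from compound 1, but no single-change step links them.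

Compound 4 `CNC(=O)[C@H]1O[C@@H](n2cnc3c(NCc4cc(Cl)cc(Cl)c4)ncnc32)[C@H](O)[C@@H]1N` has not yet been measured in this assay. Its difference from compound 1 is amino in place of hydroxy on a saturated ring carbon, an amino in place of hydroxy on a saturated ring carbon of the five-membered non-aromatic ring. Among the measured compounds shown here, none of the measured steps touches this place: the only counted step, from compound 1 to compound 2, concerns the group on the saturated chain carbon bound to a nitrogen on the aromatic ring and is within the scatter, so it does not bear on the present change. For the measured compounds named here, with no comparable step at hand, the expectation for compound 4 is a weaker inhibition than compound 1, that is a higher number, with wide uncertainty. Compound 4 is therefore estimated at 30 nM (range 5 nM to 300 nM), which means an expected step of a 12-fold higher number from compound 1 to compound 4 (1.08 log units; beyond the scatter).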

Compound 4, inhibition constant: 25 nM
The estimate for compound 4 lay 1.2-fold (0.08 log units) above the measured number; the measured number falls inside the stated range.
By their numbers in this assay, from the lowest: compounds 1 and 2 (each within the scatter of the next); then compound 4; then compound 3.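

In this assay, among these compounds, the step of a 10-fold higher number from compound 1 to compound 4 (1.00 log units; beyond the scatter) gives the first reading at this position, the saturated ring carbon next to the ring atom that bears a methylcarbamoyl group, and it lies beyond the scatter. Amino in place of hydroxy leaves the counts of heavy atoms, hydrogen-bond donors and hydrogen-bond acceptors unchanged, so the number at this position responds to an exchange that those counts do not register. Nothing measured here accounts for this shift.

On these data alone, it remains open whether a methoxy group, a fluorine or an acetamide on this ring carbon would give a number nearer to that of compound 1 or further from it. Also open, as far as these compounds go, is whether the same exchange would shift the number as much when the 2,5-dimethoxyphenyl group of compound 2 is present.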